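A few compounds are considered here, and "the series" means these few. Any claim that something is new, unique, unknown or untested is made for them only; others in the source may bear on it.

Compound 1 `COc1cccc(/C=C2\CCC/C(=C\c3ccccc3Cl)C2=O)c1OC` in a functional assay on A549 cells (Homo sapiens) for cytotoxicity, read by MTT assay, with a stated time of 72 h (on this read-out lower numbers stand for stronger inhibition and higher numbers for weaker inhibition), gives > 20000 nM, a limit of the assay rather than a number.
Compound 2 `COc1cccc(/C=C2\CCC/C(=C\c3cc(Cl)cc(Cl)c3)C2=O)c1OC` gives 12500 nM.
Compound 3 `COc1ccc(/C=C2\CCC/C(=C\c3ccccc3Br)C2=O)cc1OC` gives > 20000 nM, again a limit and not a number.

Compound 3 thus sits at the limit, where the limit of > 20000 nM in this assay, at which 2 of the 3 values shown sit, also places compound 1, so only compound 2 offers a real number. Compound 4 `COc1ccc(/C=C2\CCC/C(=C\c3ccc(O)c(Cl)c3)C2=O)cc1OC` differs from compound 3 by 3-chloro-4-hydroxyphenyl in place of 2-bromophenyl on a double-bonded chain carbon bound to a double-bonded ring carbon. Among the measured compounds shown here, the single measured step, an at least 1.6-fold lower number from compound 1 to compound 2 (0.20 log units; that floor lies within the scatter), likewise exchanged one chlorophenyl for a differently substituted one, and its size stays within the scatter, so it guides only weakly; the hydrogen-bond donor entering in compound 4 has no measured counterpart. Compound 4 is expected to move by an at least 1.3-fold lower number from compound 3 to compound 4 (0.12 log units; that floor lies within the scatter), a modestly lower number that may still return only a limit. The estimate for compound 4 is 15000 nM, between 6000 nM and 40000 nM.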

Compound 4, half-maximal inhibitory concentration: > 20000 nM
Compound 4: only a limit was reported; the forecaster's own chance of this, stated with the estimate: 45%; middle value at least 1.3-fold (0.12 log units) away from the limit.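

Compound 3 and compound 4 each return only a limit of the assay, so the step between them cannot be read. On these data alone, whether 3-chloro-4-hydroxyphenyl or 2-bromophenyl gives the lower number in this assay stays open.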